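Chloro added to the phenyl of compound 2: expectation

This account rests on a few compounds, and the source may have more. Where it says the series, first, only, none or still open, it means among the compounds named here.

Compound 2 `CN(C)CCn1cnnc1-c1cc(Oc2ccc(NC(=O)N/N=C/c3ccccc3)cc2F)ccn1` holds the lowest of the three numbers measured in a functional assay on HT-29 cells (Homo sapiens) for cytotoxicity, read by MTT assay, with a stated time of 72 h (a higher number here means a weaker inhibitor, a lower number a stronger inhibitor), at 1120 nM. Compound 1 `COc1ccc(/C=N/NC(=O)Nc2ccc(Oc3ccnc(-c4nncn4CCN(C)C)c3)c(F)c2)c(OC)c1` gives 1780 nM, and compound 3 `Cn1ncnc1-c1cc(Oc2ccc(NC(=O)N/N=C/c3ccccc3)cc2F)ccn1` gives 30200 nM. Compound 4 `CN(C)CCn1cnnc1-c1cc(Oc2ccc(NC(=O)N/N=C/c3ccc(Cl)cc3)cc2F)ccn1` differs from compound 2 by chloro in place of hydrogen on an aromatic carbon. Among the measured compounds shown here, the one measured change on that same ring, a 1.6-fold lower number from compound 1 to compound 2 (0.20 log units; within the scatter), left the read-out essentially unmoved. The large shift, a 27-fold higher number from compound 2 to compound 3 (1.43 log units; beyond the scatter), sits elsewhere in the shared core and does not bear on this position. Nothing measured speaks for a move beyond the scatter, so the step of a 1.1-fold lower number from compound 2 to compound 4 (0.05 log units; within the scatter) is expected to be small, without a clear direction. Compound 4 is therefore expected to give 1000 nM, within a range from 400 nM to 2500 nM.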

Compound 4, half-maximal inhibitory concentration: 530 nM
Beside the measured number, compound 4's estimate is 1.9-fold (0.28 log units) above it; low and high end bracket the measured number.
By their numbers in this assay, from the lowest: compound 4; then compounds 2 and 1 (each within the scatter of the next); then compound 3.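

The terminal ring in this assay now shows a step beyond the scatter: chloro in place of hydrogen, para to a large group, gives a modest change (a 2.1-fold lower number from compound 2 to compound 4 (0.32 log units; beyond the scatter)) in the direction of a stronger inhibitor. The 4-chlorophenyl group also separates from 2,4-dimethoxyphenyl (a 3.4-fold lower number from compound 1 to compound 4 (0.53 log units; beyond the scatter)), so this ring can move the read-out, which the phenyl and 2,4-dimethoxyphenyl pair alone did not show. No measurement available explains the shift.

Still open, on these data alone, is whether the gain is specific to chloro or would extend to bromo, methyl or a carboxylic acid at that carbon. Also open, as far as these compounds go, is whether chloro carries over to the core of compound 3.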